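The compounds below may be only part of what the source reports. "The series", "measured", "known", "first", "only" and "open" are said of these compounds alone.

Measured compounds:
compound 1 `O=S(=O)(c1ccc(F)cc1)n1c(-c2cn(-c3ccccc3)nc2-c2ccc(F)cc2)nc2ccccc21` gives 2370 nM
compound 2 `O=S(=O)(c1ccc(Br)cc1)n1c(-c2cn(-c3ccccc3)nc2-c2ccc(F)cc2)nc2ccccc21` gives 1720 nM

Going by the values given here, both values come from a functional assay on A549 cells (Homo sapiens) for antiproliferative activity, read by MTT assay, with a stated time of 24 h (on this read-out higher numbers stand for weaker inhibition and lower numbers for stronger inhibition), and lie within the scatter of each other, so compound 2 cannot be told apart from compound 1 on the only two numbers available. Compound 3 `O=S(=O)(c1ccc(C(F)(F)F)cc1)n1c(-c2cn(-c3ccccc3)nc2-c2ccc(F)cc2)nc2ccccc21` is unmeasured. It carries trifluoromethyl in place of bromo on an aromatic carbon, para to a large group (trifluoromethyl in place of bromo on an aromatic carbon), and the change reads 4-bromophenyl to 4-(trifluoromethyl)phenyl. Among the compounds with values here, the one measured step bearing on this is bromo in place of fluoro on an aromatic carbon, a 1.4-fold lower number from compound 1 to compound 2 (0.14 log units; within the scatter), which stays within the scatter. Within the data shown here, this is thin evidence, and no measured compound carries trifluoromethyl. No step beyond the scatter is therefore expected in this assay for this change. The estimated move is a 1.2-fold higher number from compound 2 to compound 3 (0.07 log units; within the scatter) and would remain within the scatter. For compound 3 the expected value is 2000 nM, with an estimated range of 950 nM to 4200 nM as its bounds.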

Compound 3, half-maximal inhibitory concentration: 1280 nM
For compound 3 the middle estimate is 1.6-fold (0.19 log units) above the measured one; low and high end bracket the measured number.
By their numbers in this assay, from the lowest: compounds 3, 2 and 1 (each within the scatter of the next).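

In this assay the aromatic carbon para to a large group accepts trifluoromethyl, four heavy atoms in place of the single one of bromo, with a 1.3-fold lower number from compound 2 to compound 3 (0.13 log units; within the scatter) as the whole effect. Against fluoro, the same group gives a 1.9-fold lower number from compound 1 to compound 3 (0.27 log units; within the scatter) as well, so the three substituents now shown at this place cannot be told apart on these numbers. No data on any property of these groups bear on this result.

Bromo and trifluoromethyl both count no hydrogen-bond donors, no hydrogen-bond acceptors and no net charge, so it stays open whether an amine or a carboxylic acid on this carbon would move the number beyond the scatter. Also open, as far as these compounds go, is whether a longer chain here would do so, and whether this insensitivity would persist with changes elsewhere on the shared core.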